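Cytotoxicity of a substituted nucleoside series on HEL cells

A few compounds are considered here, and "the series" means these few. Any claim that something is new, unique, unknown or untested is made for them only; others in the source may bear on it.

Measured compounds in a functional assay on HEL cells (Homo sapiens) for cytotoxicity, read by microscopy; on this read-out higher numbers stand for lower toxicity in this test and lower numbers for higher toxicity in this test:
compound 1, `CCNC(=O)NC1=CS(=O)(=O)O[C@@]12[C@@H](CO[Si](C)(C)C(C)(C)C)O[C@@H](n1cc(C)c(=O)n(C)c1=O)[C@@H]2O[Si](C)(C)C(C)(C)C`: >= 3200 nM
compound 2, `Cc1cn([C@@H]2O[C@H](CO[Si](C)(C)C(C)(C)C)[C@@]3(OS(=O)(=O)C=C3NC(=O)c3ccccc3)[C@H]2O[Si](C)(C)C(C)(C)C)c(=O)n(C)c1=O`: >= 3200 nM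
compound 3, `Cc1cn([C@@H]2O[C@H](CO[Si](C)(C)C(C)(C)C)[C@@]3(OS(=O)(=O)C=C3NC(N)=O)[C@H]2O[Si](C)(C)C(C)(C)C)c(=O)n(C)c1=O`: 16000 nM

Compound 1 stands only at a limit of this assay. Its value of >= 3200 nM is a limit and not a number. Compound 2 likewise sits at a limit, >= 3200 nM. Compound 3 alone gives a number, 16000 nM. Two of the three values shown therefore sit at the limit of >= 3200 nM in this assay, at which 2 of the 3 values shown sit, and every step among the measured compounds is left unreadable by those limits: a step that the two limits leave unreadable from compound 1 to compound 2, a step that the limit leaves unreadable from compound 1 to compound 3 and a step that the limit leaves unreadable from compound 2 to compound 3.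

The unmeasured compound 4 is `Cc1cn([C@@H]2O[C@H](CO[Si](C)(C)C(C)(C)C)[C@@]3(OS(=O)(=O)C=C3NCCC(=O)O)[C@H]2O[Si](C)(C)C(C)(C)C)c(=O)n(C)c1=O`. It differs from compound 1 by 2-carboxyethyl in place of ethylcarbamoyl on an amine nitrogen. For the measured compounds named here, the step from compound 1 to compound 3 touches the same amine nitrogen region, but its size is not readable, so no measured step gives a direction for this change. All three measured compounds show low toxicity in this assay, so compound 4 is expected to stay in the same low-toxicity region, with a step that the limit leaves unreadable from compound 1 to compound 4 expected, not distinguishable from none beyond the scatter. The estimate for compound 4 is 8000 nM, expected between 3200 nM and 32000 nM, most likely reported as a limit.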

Compound 4, minimum cytotoxic concentration: 80000 nM
For compound 4 the middle estimate is 10-fold (1.00 log units) below the measured one; the whole stated range lies below it.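

In this assay, replacing carbamoyl with 2-carboxyethyl on the amine nitrogen gives a 5.0-fold higher number from compound 3 to compound 4 (0.70 log units; beyond the scatter), so the higher number stands for lower toxicity in this test. For the compounds shown here, this is the first change on that nitrogen whose size can be read, and it shows that the position tolerates the loss of the carbonyl attached there without any rise in toxicity in this test, at least for this one pair. The steps that link compound 1 or compound 2 to compound 4 cannot be read, because the values of those two compounds are limits and not numbers: the limit of >= 3200 nM in this assay, at which 2 of the 4 values shown sit.

The compounds shown do not separate the part played by the carboxylic acid from that of the chain that carries it, since a methyl ester, a 3-aminopropyl group or a simple propyl group on the same nitrogen does not appear among them. Going by these compounds alone, whether a longer chain ending in a carboxylic acid would move the number further in this assay also stays open, as does whether the single readable step holds for any other pair.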